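From hydroxy to benzoyloxy: compound 1 and compound 4

A few compounds are considered here, and "the series" means these few. Any claim that something is new, unique, unknown or untested is made for them only; others in the source may bear on it.

Measured in an ADME assay on WiDr cells (Homo sapiens) for cytotoxicity, read by MTT assay; on this read-out higher numbers stand for an effect only at larger amounts of compound and lower numbers for an effect already at smaller amounts:
- compound 1 `C=C1CCCC(C)(C)[C@@H]1C[C@H](O)/C(C)=C/CC[C@@H]1[C@@]2(C)CCCC(C)(C)[C@@H]2CC[C@@]1(C)O`: 7.8 ug/mL
- compound 2 `C=C1CCCC(C)(C)[C@@H]1C[C@@H](O)/C(C)=C/CC[C@@H]1[C@@]2(C)CCCC(C)(C)[C@@H]2CC[C@@]1(C)O`: > 10 ug/mL, a limit of the assay and not a number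
- compound 3 `C=C1CCCC(C)(C)[C@@H]1CC(=O)/C(C)=C/CC[C@@H]1[C@@]2(C)CCCC(C)(C)[C@@H]2CC[C@@]1(C)O`: 10 ug/mL

Compound 1 gives 7.8 ug/mL and compound 3 gives 10 ug/mL, two values within the usual scatter of each other, so neither can be ranked ahead. The next compound, compound 4 `C=C1CCCC(C)(C)[C@@H]1C[C@H](OC(=O)c1ccccc1)/C(C)=C/CC[C@@H]1[C@@]2(C)CCCC(C)(C)[C@@H]2CC[C@@]1(C)O`, differs from compound 1 by benzoyl in place of hydrogen on an oxygen on a saturated carbon. In short, a hydroxy becomes a benzoyloxy, with benzoyl in place of hydrogen on an oxygen on a saturated carbon.

Among the measured compounds shown here, only one measured step bears on this change: an at least 1.2-fold higher number from compound 1 to compound 2 (0.10 log units; that floor lies within the scatter). For the measured compounds named here, that step reflects (the fact that compounds 1 and 2 differ only in the configuration as drawn), and no measured compound carries a benzoyl, so it gives no size for this change. Going by the values given here, with no measured step pointing either way, the starting point remains compound 1 at 7.8 ug/mL, and no shift beyond the scatter is expected. The expected change is a 1.0-fold higher number from compound 1 to compound 4 (0.01 log units; within the scatter). For compound 4 the estimate is 8 ug/mL, with an expected range from 4 ug/mL to 15 ug/mL.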

Compound 4, concentration for half-maximal effect: > 10 ug/mL
Compound 4: a limit, no number; the forecaster's own chance of this, stated with the estimate: 35%; middle value at least 1.2-fold (0.09 log units) from the limit.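

In this assay compound 4 gives > 10 ug/mL, which is a limit of the assay and not a number. Benzoyl in place of hydrogen on this oxygen is the first change of group here, where the earlier step changed only the configuration, and it gives an at least 1.2-fold higher number from compound 1 to compound 4 (0.10 log units; that floor lies within the scatter), so this change gave no readable value and the floor of the step does not clear the scatter. The true size of the step stays unknown because the reading stops at the limit: the limit of > 10 ug/mL in this assay, at which 2 of the 4 values shown sit.

On these data alone, it remains open whether a smaller acetyl in place of the benzoyl would give a readable value in this assay. An amine in place of the hydroxy, or a benzoyl carrying a carboxylic acid, is also untested among the compounds shown.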